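The source may report more compounds than this note shows. Statements on the series, on what has been measured and on what is new or still open speak of the compounds shown alone.

In an ADME assay on L6 cells (Rattus norvegicus) for cytotoxicity, with a stated time of 72 h (a lower number here means a stronger inhibitor, a higher number a weaker inhibitor), compound 1 (`CCN(CC)CC(=O)OC1CC2(N3CCCCC3)CC(c3ccccc3)C1C(c1ccccc1)C2`) gives 23900 nM and compound 2 (`CN(C)C12CC(OC(=O)C(C)(C)C)C(C(c3ccccc3)C1)C(c1ccccc1)C2`) gives 5060 nM, the lower of the two numbers, with the gap beyond the scatter. Compound 3 (`CC(C)(C)C(=O)OC1CC2(N3CCCCC3)CC(c3ccccc3)C1C(c1ccccc1)C2`) has piperidin-1-yl in place of dimethylamino on a saturated ring carbon. Among the measured compounds shown here, no measured step isolates this change. Compound 1 also bears piperidin-1-yl and gives 23900 nM, but its ester differs too, so it is only a loose guide. A small move to a higher number in this assay is expected, possibly none beyond the scatter. The expected change is a 1.5-fold higher number from compound 2 to compound 3 (0.17 log units; within the scatter). For compound 3 the estimate is 7500 nM, within an expected range of 2800 nM to 20000 nM.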

Compound 3, half-maximal inhibitory concentration: 12000 nM
The estimate for compound 3 lay 1.6-fold (0.20 log units) below the measured number, within the range that was stated.
By their numbers in this assay, from the lowest: compound 2; then compounds 3 and 1 (each within the scatter of the next).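

In this assay, piperidin-1-yl in place of dimethylamino on a saturated ring carbon gives a 2.4-fold higher number from compound 2 to compound 3 (0.38 log units; beyond the scatter) and shows that this position responds to the amine, though only modestly. With piperidin-1-yl held fixed, tert-butyl in place of (diethylamino)methyl on a carbonyl carbon gives a 2.0-fold lower number from compound 1 to compound 3 (0.30 log units; within the scatter) and leaves the two compounds unseparated. No measurement bearing on the cause of either step is available.

Open, going by these compounds, is how a morpholine ring or a primary amine on the same ring carbon would read here. On these data alone, a carboxylic acid or a longer chain in place of tert-butyl on the carbonyl carbon is also open.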